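Aryl and Benzyl Groups on the Ring Nitrogen

The source may hold more compounds than are shown below. What is called first, only, known or untested is meant among the compounds shown, and "the series" means these compounds.

Compound 1 `O=C1CC(c2nc(-c3cccc(Cl)c3)no2)CN1c1cccc(Cl)c1`: 1100 nM in an in vitro functional assay on HEK293-A cells for negative allosteric modulation of metabotropic glutamate receptor 5 (Homo sapiens), read by FLIPR and calcium flux; on this read-out higher numbers stand for weaker inhibition and lower numbers for stronger inhibition
Compound 2 `O=C1CC(c2nc(-c3cccc(Cl)c3)no2)CN1c1ccc(Cl)c(Cl)c1`: > 10000 nM in this assay, a limit only
Compound 3 `O=C1CC(c2nc(-c3cccc(Cl)c3)no2)CN1Cc1ccc(F)cc1`: 3600 nM in this assay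

Compound 3 stands highest of the two numbers, with compound 1 nearest at a 3.3-fold higher number from compound 1 to compound 3 (0.51 log units; beyond the scatter). Compound 4 `Cc1ccc(N2CC(c3nc(-c4cccc(Cl)c4)no3)CC2=O)cc1` differs from compound 3 by 4-methylphenyl in place of 4-fluorobenzyl on an amide-type nitrogen in a ring. For the measured compounds named here, two measured steps bear on this return from a benzyl to a phenyl group on the ring nitrogen: a 3.3-fold higher number from compound 1 to compound 3 (0.51 log units; beyond the scatter) and an at least 2.7-fold lower number from compound 2 to compound 3 (0.44 log units; beyond the scatter), which pull in opposite directions. A modest step is therefore expected in this assay, most likely toward a lower number, a 1.4-fold lower number from compound 3 to compound 4 (0.16 log units; within the scatter). Compound 4 is expected to give about 2500 nM in this assay, within 700 nM to 9000 nM.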

Compound 4, half-maximal inhibitory concentration: > 10000 nM
Compound 4: only a limit was reported; the forecaster's own chance of this, stated with the estimate: 20%; middle value at least 4.0-fold (0.60 log units) away from the limit.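

With 4-methylphenyl on the amide-type nitrogen, this assay shows an at least 9.0-fold higher number from compound 1 to compound 4 (0.95 log units; beyond the scatter) and an at least 2.7-fold higher number from compound 3 to compound 4 (0.44 log units; beyond the scatter) and so extends the loss of inhibition beyond the 3,4-dichlorophenyl group. A phenyl group on this nitrogen is therefore not enough to keep a measurable value, as compound 1 alone among the phenyl compounds shown gives one. Compound 4, like compound 2, gives only a limit, and the step between them cannot be read: the limit of > 10000 nM in this assay, at which 2 of the 4 values shown sit.

Going by these compounds, whether 3-methylphenyl would behave like 3-chlorophenyl remains open. So does whether 4-methylbenzyl, or a longer chain carrying the aromatic ring, would behave like 4-fluorobenzyl.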